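Benzylamino gives way to 3,4-difluorophenyl on a carbonyl carbon

A few compounds are considered here, and "the series" means these few. Any claim that something is new, unique, unknown or untested is made for them only; others in the source may bear on it.

In an ADME assay on Karpas-1106P cells (Homo sapiens) for cytotoxicity (a lower number here means that less compound is needed, a higher number that more compound is needed for the effect), compound 3 (`Cc1ccc(S(=O)(=O)N[C@@H](CC(=O)NC(C)(C)C)C(=O)NCCNC(=O)NCc2ccccc2)cc1`) gives > 11100 nM as its result, which is a limit and not a number. Compound 1 (`COc1cccc(C(=O)NCCNC(=O)[C@H](CC(=O)NC(C)(C)C)NS(=O)(=O)c2ccc(C)cc2)c1`) gives > 11100 nM as a limit too. Compound 2 (`Cc1ccc(S(=O)(=O)N[C@@H](CC(=O)NC(C)(C)C)C(=O)NCCNC(=O)c2ccc(Cl)cc2)cc1`) also gives > 11100 nM as a limit. The position of compound 3 is thus the limit of > 11100 nM in this assay, at which 3 of the 3 values shown sit, and nothing finer can be read. Compound 4 (`Cc1ccc(S(=O)(=O)N[C@@H](CC(=O)NC(C)(C)C)C(=O)NCCNC(=O)c2ccc(F)c(F)c2)cc1`) carries 3,4-difluorophenyl in place of benzylamino on a carbonyl carbon. The measured changes at that carbonyl carbon, a step that the two limits leave unreadable from compound 1 to compound 2 and a step that the two limits leave unreadable from compound 2 to compound 3, have no readable size. No step beyond the scatter is therefore expected in this assay and no direction is foreseen. The expected move is a step that the limit leaves unreadable from compound 3 to compound 4 as estimated here. Compound 4 is estimated at 15000 nM with a range of 7000 nM to 30000 nM and will probably report a limit again.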

Compound 4, half-maximal effective concentration: > 11100 nM
Compound 4: no number, only a limit; the forecaster's own chance of this, stated with the estimate: 85%; the middle value is on the limit's open side.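

In this assay compound 4 gives > 11100 nM as a limit, so its steps from compound 1, compound 2 and compound 3 cannot be read. Whether any group on that carbonyl carbon moves the result stays open, with all four compounds at one limit: the limit of > 11100 nM in this assay, at which 4 of the 4 values shown sit.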